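Adding a Nitro Group to Two Related Compounds

A few compounds are considered here, and "the series" means these few. Any claim that something is new, unique, unknown or untested is made for them only; others in the source may bear on it.

The study compares four compounds in a functional assay on ileum (Cavia porcellus) for antagonist activity; a lower number here means a stronger inhibitor, a higher number a weaker inhibitor. Compound 1 `Cc1ccc(OCCCOc2ccc3c(O)c([N+](=O)[O-])c(=O)oc3c2)cc1` gives 4500 nM in this assay. Compound 2 `Cc1ccc(OCCCOc2ccc3c(O)c([N+](=O)[O-])c(=O)oc3c2)c([N+](=O)[O-])c1` differs from compound 1 by nitro in place of hydrogen on an aromatic carbon. For compound 2 this assay reports only a limit, > 10000 nM. Going by these compounds, the change therefore made an at least 2.2-fold higher number from compound 1 to compound 2 (0.34 log units; beyond the scatter), a weakening whose full size stays open because of the limit of > 10000 nM in this assay, at which 1 of the 3 values shown sits.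

Compound 3 `CCCc1c(OCC(O)COc2ccc3c(O)c([N+](=O)[O-])c(=O)oc3c2C)ccc(C(C)=O)c1O` rests on a different core; the difference between the core of compound 1 and the core of compound 3 is not broken down here. In this assay compound 3 gives 25 nM, the lower of the two numbers actually measured.

Compound 4 `CCCc1c(O)c(C(C)=O)cc([N+](=O)[O-])c1OCC(O)COc1ccc2c(O)c([N+](=O)[O-])c(=O)oc2c1C` has not yet been measured in this assay. It differs from compound 3 by nitro in place of hydrogen on an aromatic carbon. Among the compounds with values here, this is the same kind of change as the one between compound 1 and compound 2, but not the same: in compound 2 the nitro group stands ortho to a large group and meta to a methyl group, whereas in compound 4 it stands ortho to a large group, meta to a propyl group, meta to an acetyl group and para to a hydroxy group.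

Within the data shown here, the one measured example of this kind of change weakened the inhibitor, as the step of an at least 2.2-fold higher number from compound 1 to compound 2 (0.34 log units; beyond the scatter) shows, so a weakening is expected here too. The expected step is a 4.0-fold higher number from compound 3 to compound 4 (0.60 log units; beyond the scatter), estimated as a modest loss. Compound 4 is expected to give about 100 nM in this assay, estimated to lie between 30 nM and 400 nM.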

Compound 4, half-maximal inhibitory concentration: 1600 nM
Compound 4: middle estimate off by 16-fold (1.20 log units), on the low side; measured number outside the range, above it.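

In this assay, putting nitro in place of hydrogen on an aromatic carbon gave a 64-fold higher number from compound 3 to compound 4 (1.81 log units; beyond the scatter), a large loss of inhibition. In both pairs the number rose, so the direction of the change carried over from the core of compound 1 to the core of compound 3, but these two pairs show no rule beyond themselves, and whether the size of the step also carried over cannot be said: the same change on two cores in this assay, an at least 2.2-fold higher number (0.34 log units; beyond the scatter) from compound 1 to compound 2 and a 64-fold higher number (1.81 log units; beyond the scatter) from compound 3 to compound 4; the limit leaves it open whether they differ. For compound 2 the reading > 10000 nM is a limit of the assay and not a number.

The compounds shown leave open whether the loss on the core of compound 3 is specific to nitro, or whether another group on the same aromatic carbon, such as an amine, a nitrile or a carboxylic acid, would bring a step of similar size. They also leave open how much the surroundings of that carbon count, since a longer chain in place of the propyl group, or a methoxy group in place of the hydroxy group, could show whether the step in this assay depends on those neighbours.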